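Phenyl for Pyridinyl on a Shared Core: Cytotoxicity Outlook

The source may hold more compounds than are shown below. What is called first, only, known or untested is meant among the compounds shown, and "the series" means these compounds.

Compound 1 `O=C1N(CCCCCCOc2ccc(C(F)(F)F)cc2)CCN1c1cccnc1` was examined in a functional assay on cells (Homo sapiens) for cytotoxicity; a lower number here means that less compound is tolerated, a higher number that more compound is tolerated. In this assay compound 1 gives > 25000 nM, which is a limit of the assay and not a number. Compound 2 `O=C1N(CCCCCCOc2ccc(F)cc2)CCN1c1cccnc1` gives > 25000 nM in this assay, again only a limit. Compound 3 `O=C1N(CCCCCCOc2ccc(Br)cc2)CCN1c1cccnc1` gives > 25000 nM in this assay, also a limit. The step that the two limits leave unreadable from compound 1 to compound 2, the step that the two limits leave unreadable from compound 1 to compound 3 and the step that the two limits leave unreadable from compound 2 to compound 3 therefore cannot be sized, because of the limit of > 25000 nM in this assay, at which 3 of the 3 values shown sit. Compound 4 `O=C1N(CCCCCCOc2ccc(C(F)(F)F)cc2)CCN1c1ccccc1` has not yet been measured in this assay. It differs from compound 1 in one place: phenyl in place of pyridin-3-yl on an amide-type nitrogen in a ring. For the measured compounds named here, none of the measured steps changes this part of the shared core, and each of them is unreadable, so they give no size for the step from compound 1 to compound 4; the step that the limit leaves unreadable from compound 1 to compound 4 is expected to lie within the scatter. Given that every measured compound sits at the limit, compound 4 is expected to give about 30000 nM, with a range from 12000 nM to 100000 nM.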

Compound 4, half-maximal cytotoxic concentration: > 25000 nM
Compound 4 gave a limit, no number (the forecaster's own chance of this, stated with the estimate: 80%); the middle value lies beyond the limit too.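

Compound 4, like compound 1, gives only a limit in this assay, so no size can be read for the exchange of pyridin-3-yl for phenyl: the limit of > 25000 nM in this assay, at which 4 of the 4 values shown sit. The compounds shown leave open where the true cytotoxic concentration of any of them lies, and whether phenyl and pyridin-3-yl differ at all.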